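A few compounds are considered here, and "the series" means these few. Any claim that something is new, unique, unknown or untested is made for them only; others in the source may bear on it.

Measured in a functional assay on HL-60 cells (Homo sapiens) for antiproliferative activity, with a stated time of 72 h; a higher number here means a weaker inhibitor, a lower number a stronger inhibitor:
- compound 1 `CCN(C)Cc1c(OC)cc(OC)c(C(=O)/C=C/c2ccccc2Cl)c1O` gives 200 nM
- compound 2 `COc1cc(OC)c(C(=O)/C=C/c2ccccc2Cl)c(O)c1CN(C)CCCN(C)C` gives 11400 nM
- compound 3 `COC(=O)CN(C)Cc1c(OC)cc(OC)c(C(=O)/C=C/c2ccccc2Cl)c1O` gives 400 nM

Compound 2 stands at the highest number of the three and is the weakest inhibitor here, with a 29-fold lower number from compound 2 to compound 3 (1.45 log units; beyond the scatter) and a 57-fold higher number from compound 1 to compound 2 (1.76 log units; beyond the scatter) both beyond the scatter. Compound 4 `COc1cc(OC)c(C(=O)/C=C/c2ccccc2Cl)c(O)c1CN1CCCC1` is not yet measured; it differs from compound 2 by pyrrolidin-1-yl in place of (3-(dimethylamino)propyl)(methyl)amino on a saturated chain carbon bound to an aromatic carbon.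

The step bears most closely on the step from compound 2 to compound 3, which removed the 2-(dimethylamino)ethyl arm and gave a 29-fold lower number from compound 2 to compound 3 (1.45 log units; beyond the scatter), and on the reverse of a 57-fold higher number from compound 1 to compound 2 (1.76 log units; beyond the scatter). Compound 4, carrying a pyrrolidin-1-yl without that arm, is therefore expected to return toward the level of compound 1; the estimated step is a 46-fold lower number from compound 2 to compound 4 (1.66 log units; beyond the scatter). Compound 4 is estimated at 250 nM, in the range 90 nM to 800 nM.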

Compound 4, half-maximal inhibitory concentration: 14200 nM
Estimate against measurement, compound 4: 57-fold (1.75 log units) below; the measured number lies above the stated range.
By their numbers in this assay, from the lowest: compounds 1 and 3 (each within the scatter of the next); then compounds 2 and 4 (each within the scatter of the next).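

Losing the (3-(dimethylamino)propyl)(methyl)amino arm does not by itself restore activity at this saturated chain carbon bound to an aromatic carbon: pyrrolidin-1-yl gives a 1.2-fold higher number from compound 2 to compound 4 (0.10 log units; within the scatter). The weak level of compound 2 is therefore not specific to that arm, and the open-chain amines of compounds 1 and 3 stand apart from the ring, with a 71-fold higher number from compound 1 to compound 4 (1.85 log units; beyond the scatter) and a 36-fold higher number from compound 3 to compound 4 (1.55 log units; beyond the scatter). No measured evidence accounts for this split.

From the compounds shown here alone, whether the drop belongs to ring closure generally stays open. Piperidin-1-yl, morpholin-4-yl or azetidin-1-yl at this place would test that, and dimethylamino would show how small an open-chain amine can be.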